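The compounds below may be only part of what the source reports. "The series", "measured", "known", "first", "only" and "open" are said of these compounds alone.

Compound 1 `O=C1OC(Cc2nc(Cc3ccccc3)no2)c2ccccc21` gives > 10000 nM in a functional assay on RAW264.7 cells (Mus musculus) for inhibition, read by Griess assay, with stated times of 1 h and 24 h (a lower number here means a stronger inhibitor, a higher number a weaker inhibitor), a limit of the assay rather than a number.
Compound 2 `O=C1OC(Cc2nc(-c3ccc(-c4ccccc4)cc3)no2)c2ccccc21` gives > 10000 nM in this assay, again a limit.
Compound 3 `CCOc1ccc(C(O)C2OC(=O)c3c(OC)cc(OC)cc32)cc1` gives > 10000 nM in this assay, also a limit.

All three measured values sit at the same point, (the limit of > 10000 nM in this assay, at which 3 of the 3 values shown sit), so none of them is a number that could be ordered against another, and compound 3 stands where every measured compound here stands: at the limit, with no measured inhibition to speak of.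

Compound 4 `COc1cc(OC)c2c(c1)C(C(O)c1ccc(OCCOc3ccccc3)cc1)OC2=O` is the unmeasured compound. It differs from compound 3 in one place (phenoxy in place of hydrogen on a saturated chain carbon, two bonds along the chain from an oxygen on an aromatic ring). Among the compounds with values here, no measured pair of compounds here differs in a single place, so there is no measured step to lean on for the size of this change. With compound 3 giving > 10000 nM, the step from compound 3 to compound 4 is expected to be small or none beyond the scatter, an at least 1.1-fold lower number from compound 3 to compound 4 (0.04 log units; that floor lies within the scatter), though a gain cannot be excluded. Compound 4 is therefore expected to give about 9000 nM in this assay, in a range from 2000 nM to 30000 nM.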

Compound 4, half-maximal inhibitory concentration: > 10000 nM
Compound 4 was reported as a limit; the forecaster's own chance of this, stated with the estimate: 60%; middle value at least 1.1-fold (0.04 log units) from the limit.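

Compound 3 and compound 4 both sit at a limit of the assay rather than at a number, so no step can be read between them: the limit of > 10000 nM in this assay, at which 4 of the 4 values shown sit.

Whether phenoxy in place of hydrogen changes inhibition at all stays open, as does what would bring any of these compounds to a real number in this assay.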